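The compounds below may be only part of what the source reports. "The series", "measured", "known", "first", "only" and "open" are said of these compounds alone.

Measured compounds:
Compound 1, `COc1ccccc1OC(C)CNC(C)=O`: 10500 nM
Compound 2, `CC(=O)NCC(C)Oc1ccccc1`: 1380 nM
Compound 3, `COc1cccc(SCCNC(C)=O)c1`: 55 nM

These three acetamides were tested in an assay on NIH3T3 cells for displacement of a labelled ligand from melatonin receptor type 1A (Homo sapiens), with a stated time of 90 min; on this read-out higher numbers stand for weaker inhibition and lower numbers for stronger inhibition. Compound 3 gives the lowest number of the three: compound 2 sits at a number a 7.6-fold lower number from compound 1 to compound 2 (0.88 log units; beyond the scatter) below compound 1, and compound 3 lies further below both of them, with its gaps to compound 2 and to compound 1 each beyond the scatter.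

The unmeasured compound 4, `CC(=O)NCCSc1ccccc1`, arises from compound 3 by one change: hydrogen in place of methoxy on an aromatic carbon. Among the compounds with values here, the only measured step of the same kind is the one from compound 1 to compound 2, a 7.6-fold lower number from compound 1 to compound 2 (0.88 log units; beyond the scatter), where the same exchange lowered the number. That step, however, was seen on a different core, with an oxygen linker and a methyl on the chain, so it gives only a loose guide. Compound 3 already stands well below the other two, and the lone comparison does not show whether the same exchange acts alike on its core. The expected step is therefore a 5.5-fold higher number from compound 3 to compound 4 (0.74 log units; beyond the scatter) in this assay, with wide uncertainty in either direction. Compound 4 is estimated at 300 nM, in a range from 40 nM to 3000 nM.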

Compound 4, inhibition constant: 3800 nM
For compound 4 the middle estimate is 13-fold (1.10 log units) below the measured one; measured number above the stated range.
By their numbers in this assay, from the lowest: compound 3; then compound 2; then compound 4; then compound 1.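

In this assay, the exchange of methoxy for hydrogen on the aromatic carbon, meta to a group of 7 heavy atoms, gives a 69-fold higher number from compound 3 to compound 4 (1.84 log units; beyond the scatter). This shows that the methoxy group counts for a great deal at this position on this core, which the earlier pair could not show, and that the same exchange can move the number in opposite directions on two cores: the same change on two cores in this assay, a 7.6-fold lower number (0.88 log units; beyond the scatter) from compound 1 to compound 2 and a 69-fold higher number (1.84 log units; beyond the scatter) from compound 3 to compound 4, 530-fold (2.72 log units) apart, beyond the scatter of two such steps. A result for this exchange on one core is therefore a poor guide to its result on another, and each core needs its own test.

The compounds shown include no pair that differs only in the linking atom, sulfur or oxygen, or only in the methyl on the chain, so it remains open which of these differences reverses the direction of the step. On these data alone, it also remains open whether an ethoxy group, a hydroxyl group or a chlorine atom in place of the methoxy would keep a number close to that of compound 3, 55 nM, or fall back towards that of compound 4, 3800 nM.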